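A few compounds are considered here, and "the series" means these few. Any claim that something is new, unique, unknown or untested is made for them only; others in the source may bear on it.

The measured compounds in this set:

compound 1, `CSc1nc(NCCCCNc2ccnc3cc(Cl)ccc23)c(C#N)c(-c2ccccc2)n1` — 20000 nM
compound 2, `CSc1nc(OCCCNc2ccnc3cc(Cl)ccc23)c(C#N)c(-c2ccccc2)n1` — 4000 nM
compound 3, `CSc1nc(-c2ccccc2)c(C#N)c(N2CCN(c3ccnc4cc(Cl)ccc34)CC2)n1` — > 100000 nM

All three were examined in an ADME assay on Vero cells (Chlorocebus sabaeus) for cytotoxicity, read by microscopy; on this read-out higher numbers stand for lower toxicity in this test and lower numbers for higher toxicity in this test. Compound 1 gives 20000 nM, which is the highest of the two numbers actually obtained. Its nearest neighbour is compound 2, which with 4000 nM sits lower by a margin beyond the usual scatter. Compound 3 is reported only as a limit, (the limit of > 100000 nM in this assay, at which 1 of the 3 values shown sits), and not as a number.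

The account now turns to compound 4, `COc1ccc(-c2nc(SC)nc(NCCCCNc3ccnc4cc(Cl)ccc34)c2C#N)cc1OC`, which is to be measured in this assay. It differs from compound 1 in one place: 3,4-dimethoxyphenyl in place of phenyl on an aromatic carbon. Among the compounds with values here, no measured pair in this set shows what this change does in this assay, so the expectation rests on the number for compound 1 alone. The step from compound 1 to compound 4 is expected to be small, no change at the digits printed from compound 1 to compound 4 (within the scatter), in no clear direction and not beyond the scatter. The estimate for compound 4 in this assay is therefore 20000 nM, with a plausible range from 7000 nM to 60000 nM.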

Compound 4, minimum cytotoxic concentration: > 100000 nM
Compound 4 gave a limit, no number; the forecaster's own chance of this, stated with the estimate: 10%; middle value at least 5.0-fold (0.69 log units) away from the limit.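

In this assay, within the data shown here, no earlier pair varied the aromatic carbon ortho to a cyano group, so compounds 1 to 3 gave no hint of what a change there would do. Replacing phenyl with 3,4-dimethoxyphenyl at this place gives an at least 5.0-fold higher number from compound 1 to compound 4 (0.69 log units; beyond the scatter), which shows that the read-out is sensitive to this position and that this change moves it towards lower toxicity in this test. Compound 4 stands at a limit of the assay and not at a number, so the full size of the step remains unread: the limit of > 100000 nM in this assay, at which 2 of the 4 values shown sit.

This single pair cannot separate the effect of the two methoxy groups from one another, and it leaves open whether a single methoxy group, a hydroxyl group, an amine or a fluorine on the phenyl ring would move the read-out in the same way. As far as these compounds go, whether the same exchange would act alike on compound 2, with its different chain, also remains open.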